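A few compounds are considered here, and "the series" means these few. Any claim that something is new, unique, unknown or untested is made for them only; others in the source may bear on it.

Measured compounds:
- compound 1 `CC(=O)c1cccc(OCc2cccc(Br)c2)c1`: 49.1%
- compound 2 `CC(=O)c1cccc(OCc2cccc(C)c2)c1`: 31.1%

In an assay on isolated protein for inhibition of Amine oxidase [flavin-containing] A (Homo sapiens), read by Amplex Red, with a stated time of 15 min, tested at 100 uM (a lower number here means less inhibition, a higher number more inhibition at the concentration tested (going by the name of the read-out)), compound 1 gives 49.1%, and compound 2 gives 31.1%. Compound 2 thus stands lowest of the two measured compounds, and its nearest neighbour is compound 1; the step of a number 18 percentage points lower from compound 1 to compound 2 (beyond the scatter) separates them.

Compound 3 `CC(=O)c1cccc(OCc2cccc(C(F)(F)F)c2)c1` has not yet been measured. It differs from compound 2 in one place: trifluoromethyl in place of methyl on an aromatic carbon.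

Among the compounds with values here, only one measured step bears on this change, the one from compound 1 to compound 2, in which methyl took the place of bromo at the same aromatic carbon and the read-out went a number 18 percentage points lower from compound 1 to compound 2 (beyond the scatter). That step shows that the group at this position moves the read-out by a modest amount, and that methyl gave the lower number. Within the data shown here, replacing methyl with trifluoromethyl is therefore expected to move the read-out in this assay upward by a modest amount, though no step with trifluoromethyl itself is available, so the range is kept wide. For compound 3 the estimate is 42%, between 25% and 60%, a step of a number 10.9 percentage points higher from compound 2 to compound 3 (beyond the scatter) expected from compound 2.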

Compound 3, a percentage reported as inhibition, at one concentration (the size of the read-out at that concentration, not a potency): 46.7%
Compound 3: the middle estimate sits 4.7 percentage points below what was measured; low and high end bracket the measured number.
By their numbers in this assay, from the lowest: compound 2; then compounds 3 and 1 (each within the scatter of the next).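

In this assay, within the data shown here, the change of methyl to trifluoromethyl gives a number 15.6 percentage points higher from compound 2 to compound 3 (beyond the scatter) and so adds a second group that stands clear of methyl at this aromatic carbon, where the earlier compounds offered only bromo for comparison. Trifluoromethyl and bromo, by contrast, cannot be told apart here, with a number 2.4 percentage points lower from compound 1 to compound 3 (within the scatter) in this assay. Among the three groups, methyl alone therefore stands apart, with both of its steps beyond the scatter, while the other two give matching read-outs despite being different groups. Nothing available here bears on why the read-out follows these groups.

The compounds shown leave open whether a polar group such as an amine or a carboxylic acid, or a longer chain such as ethyl, would match bromo and trifluoromethyl at this carbon, match methyl, or fall outside both. They also leave open whether the gap seen with methyl would hold on a changed core, and, as each read-out comes from one concentration, how these compounds compare in potency.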